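The compounds below may be only part of what the source reports. "The series", "measured", "known", "first", "only" and "open" are said of these compounds alone.

Measured compounds:
compound 1, `COC(C)(C)[C@@H](O)C(=O)N1[C@H](C(=O)NCc2cc(Cl)ccc2-n2cnnn2)C[C@@H]2C[C@@H]21`, 1000 nM
compound 2, `CCCC[C@@H](O)C(=O)N1N=CC[C@H]1C(=O)NCc1cc(Cl)ccc1-n1cnnn1`, 610 nM
compound 3, `COC(C)(C)[C@@H](O)C(=O)N1N=CC[C@H]1C(=O)NCc1cc(Cl)ccc1-n1cnnn1`, 3700 nM

All three were tested in a functional assay on a cell-free system (plasma, Homo sapiens), with a stated time of 3 min; a lower number here means a stronger inhibitor, a higher number a weaker inhibitor. Compound 3 stands at the top of the three numbers: it is higher than compound 1 and furthest from compound 2, and both gaps lie beyond the usual scatter, so compound 3 is the weakest inhibitor among the measured compounds.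

Compound 4, `CC1(C[C@@H](O)C(=O)N2N=CC[C@H]2C(=O)NCc2cc(Cl)ccc2-n2cnnn2)CC1`, has not yet been measured. It differs from compound 3 in one place: (1-methylcyclopropyl)methyl in place of 1-methoxy-1-methylethyl on a saturated chain carbon bound to a carbonyl carbon and an oxygen on a saturated carbon.

Among the measured compounds shown here, one measured step bears on this change. The step of a 6.1-fold higher number from compound 2 to compound 3 (0.78 log units; beyond the scatter) shows that putting a group carrying an oxygen on this carbon, in place of butyl, weakened inhibition by a modest but real amount. The step from compound 3 to compound 4 goes the other way: the group with the oxygen leaves and a group of carbon only enters. Compound 4 is therefore expected to give a lower number than compound 3 in this assay, with a step of roughly a 4.6-fold lower number from compound 3 to compound 4 (0.67 log units; beyond the scatter), somewhat short of a full reversal since the entering group is not butyl itself. The estimate for compound 4 is 800 nM, within a range from 350 nM to 1800 nM.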

Compound 4, half-maximal inhibitory concentration: 730 nM
Compound 4: the middle estimate sits 1.1-fold (0.04 log units) above what was measured; the measured number falls inside the stated range.
By their numbers in this assay, from the lowest: compounds 2, 4 and 1 (each within the scatter of the next); then compound 3.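

In this assay, among the compounds shown here, the earlier compounds showed only that 1-methoxy-1-methylethyl gave a weaker inhibitor than butyl on a saturated chain carbon bound to a carbonyl carbon and an oxygen on a saturated carbon; the new result shows that this loss can be recovered with a group that contains a ring. The change gives a 5.1-fold lower number from compound 3 to compound 4 (0.70 log units; beyond the scatter), with the heavy-atom count unchanged, while the oxygen leaves and a three-membered non-aromatic ring of carbon only enters. Set against the butyl compound, the ring makes no difference that can be told apart from the scatter, as the change gives a 1.2-fold higher number from compound 2 to compound 4 (0.08 log units; within the scatter), so 1-methylcyclopropyl and propyl at the end of this chain cannot be separated in this assay.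

Nothing shown gives a reason for either step. As far as these compounds go, it remains open whether the oxygen or the branching of 1-methoxy-1-methylethyl goes with the higher number of compound 3, which a tert-butyl group or a 2-methoxyethyl chain at this carbon could help to separate, and whether (1-methylcyclopropyl)methyl would bring a similar step on the core of compound 1.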